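Hydroxypropyl to dimethylaminoethyl on the ring nitrogen chain

The source may hold more compounds than are shown below. What is called first, only, known or untested is meant among the compounds shown, and "the series" means these compounds.

Measured so far:
- compound 1 `COc1cccc(CNC(=O)c2[nH]c3nc(-c4cn[nH]c4)ccc3c2CN2CCN(C)CC2)c1`: 8 nM
- compound 2 `COc1cccc(CNC(=O)c2cc3ccc(-c4cn[nH]c4)nc3n2CCCO)c1`: 24 nM
- compound 3 `COc1cccc(CN(C(=O)c2cc3ccc(-c4cn[nH]c4)nc3[nH]2)C2CC2)c1`: 8 nM

The three compounds share a core and were all tested in an assay on isolated protein for inhibition of Rho-associated protein kinase 2 (Homo sapiens); a lower number here means a stronger inhibitor, a higher number a weaker inhibitor. Compound 2 carries the highest number of the three. Its nearest neighbour on the numbers is compound 1, whose value lies lower by a step beyond the scatter, and compound 3 lies lower by the same margin. None of the three pairs differs in only one place, so no single structural step can be read from the measured set.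

Compound 4 `COc1cccc(CNC(=O)c2cc3ccc(-c4cn[nH]c4)nc3n2CCN(C)C)c1` is not yet measured. It differs from compound 2 in one place: dimethylamino in place of hydroxymethyl on a saturated chain carbon, two bonds along the chain from an aromatic nitrogen. Within the data shown here, the measured compounds give no direct precedent for this exchange. The expectation for compound 4 is a move toward the lower numbers of compounds 1 and 3, a step of a 2.0-fold lower number from compound 2 to compound 4 (0.30 log units; within the scatter) that may only just clear the scatter. Compound 4 is estimated at 12 nM, with a range from 5 nM to 35 nM.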

Compound 4, half-maximal inhibitory concentration: 43 nM
Beside the measured number, compound 4's estimate is 3.6-fold (0.55 log units) below it; measured number above the stated range.
By their numbers in this assay, from the lowest: compounds 1 and 3 (each within the scatter of the next); then compounds 2 and 4 (each within the scatter of the next).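

In this assay, dimethylamino in place of hydroxymethyl on a saturated chain carbon, two bonds along the chain from an aromatic nitrogen, reads as a 1.8-fold higher number from compound 2 to compound 4 (0.25 log units; within the scatter), so this exchange gives no measurable change. At this position, 3-hydroxypropyl and 2-(dimethylamino)ethyl cannot be told apart, and the hydrogen-bond donor of hydroxymethyl shows no effect in this single pair. No available measurement bears on why the two chains read alike.

Still open, going by these compounds, is whether a carboxylic acid at the chain end, a morpholine in place of dimethylamino, or a longer chain would leave the number equally unmoved. Among these compounds, also open is how an aromatic nitrogen without any chain, as in compounds 1 and 3, compares with either chain, as no pair isolates that change.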